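This account rests on a few compounds, and the source may have more. Where it says the series, first, only, none or still open, it means among the compounds named here.

- Compound 1 `CCOCc1cc(CN2CCCC2)c(O)c2ncccc12` gives 912 nM
- Compound 2 `COCc1cc(CN2CCCCC2)c(O)c2ncccc12` gives 912 nM

Both values come from a functional assay on MES-SA/Dx5 cells (Homo sapiens) for inhibition, with a stated time of 72 h; a higher number here means a weaker inhibitor, a lower number a stronger inhibitor. Compound 2 stands at 912 nM, level with compound 1 within the scatter.

Compound 3 `CCOCc1cc(CN2CCCCC2)c(O)c2ncccc12` differs from compound 2 by methyl in place of hydrogen on a saturated chain carbon bound to an oxygen on a saturated carbon, which turns methoxymethyl into ethoxymethyl. Among the measured compounds shown here, no measured pair isolates this change, so any expectation is weakly grounded. In this assay no shift beyond the scatter is expected, in either direction. The estimated change, a 1.0-fold lower number from compound 2 to compound 3 (0.01 log units; within the scatter), is expected to be small. For compound 3 the estimate is 900 nM, with an expected range of 420 nM to 1900 nM.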

Compound 3, half-maximal inhibitory concentration: 776 nM
The estimate for compound 3 lay 1.2-fold (0.06 log units) above the measured number; the range from low to high includes it.
By their numbers in this assay, from the lowest: compounds 3, 1 and 2 (each within the scatter of the next).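

Compound 3 links compound 1 and compound 2, which differ in two places, so each change can now be read alone. In this assay methoxymethyl to ethoxymethyl gives a 1.2-fold lower number from compound 2 to compound 3 (0.07 log units; within the scatter) and piperidin-1-yl in place of pyrrolidin-1-yl gives a 1.2-fold lower number from compound 1 to compound 3 (0.07 log units; within the scatter) with neither swap moving the number beyond the scatter. No supporting data bear on this result.

Still open, going by these compounds, is whether a longer chain such as butoxymethyl on the ether side, or morpholin-4-yl in place of piperidin-1-yl, would shift the number beyond the scatter.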